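A few compounds are considered here, and "the series" means these few. Any claim that something is new, unique, unknown or untested is made for them only; others in the source may bear on it.

Compound 1 `COc1cccc(/C=C2\CCC/C(=C\c3ccccc3Cl)C2=O)c1OC`: 11300 nM
Compound 2 `COc1cccc(/C=C2\CCC/C(=C\c3cccc(Cl)c3)C2=O)c1OC`: 12000 nM
Compound 3 `COc1cccc(/C=C2\CCC/C(=C\c3ccc(Cl)cc3)C2=O)c1OC`: 10300 nM

All three values come from a functional assay on MCF7 cells (Homo sapiens) for cytotoxicity, read by MTT assay, with a stated time of 72 h; on this read-out lower numbers stand for stronger inhibition and higher numbers for weaker inhibition. Compound 3 stands level with the other two, as the data show a 1.1-fold lower number from compound 1 to compound 3 (0.04 log units; within the scatter) and a 1.2-fold lower number from compound 2 to compound 3 (0.07 log units; within the scatter). The remaining 1.1-fold higher number from compound 1 to compound 2 (0.03 log units; within the scatter) tells the same story: among these three, the place of the chlorine on the phenyl ring leaves the number where it was.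

The next compound is compound 4 `COc1cccc(/C=C2\CCC/C(=C\c3ccccc3Br)C2=O)c1OC`. It differs from compound 3 on a double-bonded chain carbon bound to a double-bonded ring carbon: 2-bromophenyl in place of 4-chlorophenyl on a double-bonded chain carbon bound to a double-bonded ring carbon. Its 2-bromophenyl group carries the same number in its name as the 2-chlorophenyl group of compound 1, which gives 11300 nM. The closest evidence is therefore a 1.1-fold lower number from compound 1 to compound 3 (0.04 log units; within the scatter), a swap between those same two named positions with chlorine kept. Within the data shown here, no measured compound here carries bromine, so the exchange of chlorine for bromine itself has no measured step behind it.

Going by compound 1 and its small step to compound 3, no shift beyond the scatter is expected in this assay. The expected step is a 1.1-fold higher number from compound 3 to compound 4 (0.03 log units; within the scatter). Compound 4 is estimated at 11000 nM, with an expected range of 6000 nM to 19000 nM.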

Compound 4, half-maximal inhibitory concentration: 9700 nM
Beside the measured number, compound 4's estimate is 1.1-fold (0.05 log units) above it; measured number inside the range.
By their numbers in this assay, from the lowest: compounds 4, 3, 1 and 2 (each within the scatter of the next).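

The exchange of halogen at this position now has a measured step of its own: in this assay, with the 2-substituted phenyl group kept, bromo in place of chloro on an aromatic carbon gives a 1.2-fold lower number from compound 1 to compound 4 (0.07 log units; within the scatter). The two steps that change the halogen and its place on the ring together read the same way, with a 1.1-fold lower number from compound 3 to compound 4 (0.03 log units; within the scatter) and a 1.2-fold lower number from compound 2 to compound 4 (0.09 log units; within the scatter). On a double-bonded chain carbon bound to a double-bonded ring carbon, the earlier compounds had shown only that moving chlorine leaves the number level, and the four compounds now show the same for 2-bromophenyl, so that neither this halogen exchange nor the combined changes separate any of them in this assay.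

What the compounds shown leave open is whether a group of another kind on this phenyl ring, such as an amine or a carboxylic acid, would move the number beyond the scatter, and whether 3-bromophenyl or 4-bromophenyl would stay level too. Nothing given here speaks to why the number holds across these halogen changes.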